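Putting an anilino group on the side chain

The source may hold more compounds than are shown below. What is called first, only, known or untested is meant among the compounds shown, and "the series" means these compounds.

Compound 1 `CCNCCCOc1ccc2cc(NC(=O)c3ccc(O)c(CC=C(C)C)c3)c(=O)oc2c1C`, compound 2 `CC(C)=CCc1cc(C(=O)Nc2cc3ccc(OCCCNC4CCCCC4)c(C)c3oc2=O)ccc1O` and compound 3 `CC(C)=CCc1cc(C(=O)Nc2cc3ccc(OCCCN(C)C4CCCCC4)c(C)c3oc2=O)ccc1O` share one core and differ only in the amino group on their side chain. In a functional assay on SK-BR-3 cells (Homo sapiens) for antiproliferative activity (on this read-out higher numbers stand for weaker inhibition and lower numbers for stronger inhibition), compound 1 gives 720 nM, compound 2 gives 660 nM and compound 3 gives 970 nM. Compound 3 stands level with the other two, as the data show a 1.3-fold higher number from compound 1 to compound 3 (0.13 log units; within the scatter) and a 1.5-fold higher number from compound 2 to compound 3 (0.17 log units; within the scatter).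

Compound 4 `CC(C)=CCc1cc(C(=O)Nc2cc3ccc(OCCCNc4ccccc4)c(C)c3oc2=O)ccc1O` has not been measured yet. It carries anilino in place of cyclohexyl(methyl)amino on a saturated chain carbon, three bonds along the chain from an oxygen on an aromatic ring.

Within the data shown here, two measured steps bear most directly on this change. One is a 1.1-fold lower number from compound 1 to compound 2 (0.04 log units; within the scatter), with cyclohexyl in place of ethyl on an amine nitrogen. The other is a 1.5-fold higher number from compound 2 to compound 3 (0.17 log units; within the scatter), with methyl in place of hydrogen on an amine nitrogen. Neither step moved the number beyond the scatter. However, no measured compound has an aromatic ring on that nitrogen, so the expectation remains loose.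

In this assay the expected change is a 1.2-fold lower number from compound 3 to compound 4 (0.08 log units; within the scatter), which would not stand out from the scatter. The estimate for compound 4 is 800 nM, with an expected range from 350 nM to 1800 nM.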

Compound 4, half-maximal inhibitory concentration: > 50000 nM
Compound 4 gave a limit, no number; the forecaster's own chance of this, stated with the estimate: 3%; middle value at least 62-fold (1.79 log units) from the limit.
By their numbers in this assay, from the lowest: compounds 2, 1 and 3 (each within the scatter of the next). At a limit, above all of these: compound 4.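

In this assay, ethyl, cyclohexyl and an added methyl on the side-chain nitrogen had all left the read-out within the scatter, so this position looked tolerant of change, but those three compounds carry only saturated groups there. A phenyl group on that nitrogen breaks the picture: the data show an at least 75-fold higher number from compound 2 to compound 4 (1.87 log units; beyond the scatter) with phenyl in place of cyclohexyl, an at least 69-fold higher number from compound 1 to compound 4 (1.84 log units; beyond the scatter) with phenyl in place of ethyl, and an at least 51-fold higher number from compound 3 to compound 4 (1.71 log units; beyond the scatter) with anilino in place of cyclohexyl(methyl)amino. Compound 4 gave a limit rather than a number, so all three steps rest on that limit: the limit of > 50000 nM in this assay, at which 1 of the 4 values shown sits.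

Going by these compounds, what stays open is whether any aromatic ring on this nitrogen has the same effect, and whether benzylamino or methyl(phenyl)amino on the same chain would read like compound 2 or like compound 4. The compounds shown also cannot tell why anilino differs so sharply from the other amino groups, since this cell read-out is the only measurement available for them.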